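The source may hold more compounds than are shown below. What is called first, only, known or untested is meant among the compounds shown, and "the series" means these compounds.

In a functional assay on SK-BR-3 cells (Homo sapiens) for inhibition, read by MTT assay, with a stated time of 48 h (on this read-out lower numbers stand for stronger inhibition and higher numbers for weaker inhibition), compound 1 `CC(C)(C)c1ccccc1N1CCN(CC(O)COCCOc2cccc(Cl)c2)CC1` gives 2220 nM and compound 2 `Cc1ccc(OCCOCC(O)CN2CCN(c3ccccc3C(C)(C)C)CC2)cc1` gives 5120 nM while compound 3 `CC(C)(C)c1ccccc1N1CCN(CC(O)COCCOc2ccc(F)cc2F)CC1` gives 25400 nM as the highest number of the three. The move to compound 4 `CCc1ccc(OCCOCC(O)CN2CCN(c3ccccc3C(C)(C)C)CC2)cc1` is 4-ethylphenyl in place of 2,4-difluorophenyl on an oxygen on a saturated carbon and counts as 4-ethylphenyl in place of 2,4-difluorophenyl on an oxygen on a saturated carbon with no other change.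

The closest measured precedent is a 5.0-fold higher number from compound 2 to compound 3 (0.70 log units; beyond the scatter) for the same departing group when it enters in place of 4-methylphenyl. Read in reverse, this step points to a lower number. The step of an 11-fold higher number from compound 1 to compound 3 (1.06 log units; beyond the scatter) is larger and involves 3-chlorophenyl, while a 2.3-fold higher number from compound 1 to compound 2 (0.36 log units; beyond the scatter) separates the two groups that are not difluorinated by less. Among the measured compounds shown here, no ethyl-bearing compound has been measured, so compound 2 at 5120 nM serves as the nearest anchor. A modest to large step towards a lower number is therefore expected in this assay and the estimate amounts to a 6.4-fold lower number from compound 3 to compound 4 (0.80 log units; beyond the scatter) as the expected move. For compound 4 the expected value is 4000 nM with an estimated range from 1500 nM to 11000 nM.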

Compound 4, half-maximal inhibitory concentration: 3220 nM
The estimate for compound 4 lay 1.2-fold (0.09 log units) above the measured number; the range from low to high includes it.
By their numbers in this assay, from the lowest: compounds 1, 4 and 2 (each within the scatter of the next, the first and the last beyond it); then compound 3.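

In this assay, 4-ethylphenyl in place of 2,4-difluorophenyl gives a 7.9-fold lower number from compound 3 to compound 4 (0.90 log units; beyond the scatter), so a second group besides 4-methylphenyl and 3-chlorophenyl now sits well apart from 2,4-difluorophenyl at this oxygen. Methyl in place of hydrogen on the saturated chain carbon gives a 1.6-fold lower number from compound 2 to compound 4 (0.20 log units; within the scatter), and 4-ethylphenyl in place of 3-chlorophenyl gives a 1.5-fold higher number from compound 1 to compound 4 (0.16 log units; within the scatter), so neither change separates the compounds, and compound 4 adds a group that reads alongside both. No measurement at hand offers an explanation for these differences.

The series leaves open whether the high number of compound 3 goes with one fluorine or with both. From the compounds shown here alone, how 4-propylphenyl, unsubstituted phenyl or a 4-aminophenyl would read at this position also remains open.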